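The compounds below may be only part of what the source reports. "The series", "measured", "known", "first", "only" and "open" are said of these compounds alone.

- Compound 1 `COc1ccc(C(N)=O)cc1/C=C/c1ccc(C)cc1`: 1600 nM
- Compound 2 `COc1ccc(C(N)=O)cc1/C=C/c1ccc(F)cc1`: 2100 nM
- Compound 3 `COc1ccc(C(N)=O)cc1/C=C/c1ccc(C#N)cc1`: not yet measured

In a functional assay on HUVEC cells (Homo sapiens) for inhibition, with a stated time of 4 days (a higher number here means a weaker inhibitor, a lower number a stronger inhibitor), compound 2 gives 2100 nM, a number within the scatter of compound 1 at 1600 nM. The account now turns to compound 3, which differs from compound 2 as follows: cyano in place of fluoro on an aromatic carbon. Going by the values given here, only one measured step bears on this change, since it also swaps the group on an aromatic carbon: a 1.3-fold higher number from compound 1 to compound 2 (0.12 log units; within the scatter). That single step gives no sign that the group at this place moves the number, although cyano itself has not yet been tested. No step beyond the scatter is therefore expected in this assay. The expected step is a 1.2-fold lower number from compound 2 to compound 3 (0.07 log units; within the scatter). Compound 3 is estimated at 1800 nM, with an expected range of 600 nM to 5000 nM.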

Compound 3, half-maximal inhibitory concentration: 3100 nM
Compound 3: middle estimate off by 1.7-fold (0.24 log units), on the low side; the range from low to high includes it.
By their numbers in this assay, from the lowest: compounds 1, 2 and 3 (each within the scatter of the next).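

In this assay the cyano group adds a third kind of group at this place, on an aromatic carbon para to a large group, and the steps stay within the scatter: there is a 1.5-fold higher number from compound 2 to compound 3 (0.17 log units; within the scatter), and there is a 1.9-fold higher number from compound 1 to compound 3 (0.29 log units; within the scatter). The earlier pair compared only fluoro with methyl, whereas cyano brings a triple bond and a hydrogen-bond acceptor, and the three compounds still cannot be told apart in this assay. No available evidence bears on this result.

The compounds shown leave open whether an amine, a carboxylic acid or a longer chain at this place would give a step beyond the scatter. They also leave open whether plain hydrogen here would read differently from these three groups.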